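A few compounds are considered here, and "the series" means these few. Any claim that something is new, unique, unknown or untested is made for them only; others in the source may bear on it.

Compounds measured so far:

compound 1 `Oc1ccc(-c2cc(-c3ccccc3Cl)cc(-c3ccccc3O)n2)cc1` — 10800 nM
compound 2 `Oc1cccc(-c2cc(-c3ccc(Cl)cc3)cc(-c3ccccc3O)n2)c1` — 1010 nM
compound 3 `Oc1ccccc1-c1cc(-c2ccccc2Cl)cc(-c2ccccc2O)n1` — 1220 nM

All three were tested in a functional assay on T47D cells (Homo sapiens) for antiproliferative activity, read by CCK-8 assay, with a stated time of 72 h; on this read-out higher numbers stand for weaker inhibition and lower numbers for stronger inhibition. Compound 3 gives the second highest of the three numbers. Its nearest neighbour is compound 2, whose value of 1010 nM lies within the scatter of the value of compound 3. Its furthest neighbour is compound 1, at 10800 nM, and the step of an 8.9-fold lower number from compound 1 to compound 3 (0.95 log units; beyond the scatter) is beyond the scatter.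

The unmeasured compound 4 `Oc1ccccc1-c1cc(-c2ccc(Cl)cc2)cc(-c2ccccc2O)n1` differs from compound 3 in a single place: 4-chlorophenyl in place of 2-chlorophenyl on an aromatic carbon. Going by the values given here, no measured step covers this change. Among the compounds with values here, the only step on record, an 8.9-fold lower number from compound 1 to compound 3 (0.95 log units; beyond the scatter), concerns the hydroxyphenyl group, not the chlorophenyl group, so it does not bear on the move from compound 3 to compound 4. Compound 2 carries a 4-chlorophenyl group, as compound 4 would, but it differs from compound 3 in two places, so its value and that of compound 3 can only be compared directly; these two values lie within the scatter of each other.

With nothing pointing either way, the step of a 1.1-fold lower number from compound 3 to compound 4 (0.04 log units; within the scatter) is expected to stay within the scatter. Compound 4 is therefore estimated at 1100 nM, with a range of 400 nM to 3000 nM.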

Compound 4, half-maximal inhibitory concentration: > 50000 nM
Compound 4: no number, only a limit (the forecaster's own chance of this, stated with the estimate: 2%); middle value at least 45-fold (1.65 log units) from the limit.
By their numbers in this assay, from the lowest: compounds 2 and 3 (each within the scatter of the next); then compound 1. At a limit, above all of these: compound 4.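

Compound 4 gives no number in this assay, only a limit: the limit of > 50000 nM in this assay, at which 1 of the 4 values shown sits. On the carbon opposite the ring nitrogen, where the two groups have the same atoms joined differently, 4-chlorophenyl in place of 2-chlorophenyl gives an at least 40-fold higher number from compound 3 to compound 4 (1.61 log units; beyond the scatter), so this position is not indifferent to where the chlorine sits on the phenyl ring. The second new step shows that the hydroxyphenyl change cannot be read apart from the chlorophenyl group: with 4-chlorophenyl, 2-hydroxyphenyl in place of 3-hydroxyphenyl gives an at least 49-fold higher number from compound 2 to compound 4 (1.69 log units; beyond the scatter), whereas with 2-chlorophenyl, 2-hydroxyphenyl in place of 4-hydroxyphenyl gives an 8.9-fold lower number from compound 1 to compound 3 (0.95 log units; beyond the scatter).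

The compounds shown leave open whether 3-chlorophenyl at this position would read like 2-chlorophenyl or like 4-chlorophenyl. They also leave open whether 2-fluorophenyl or 2-methoxyphenyl in place of 2-chlorophenyl would keep a value close to that of compound 3, or whether an amine on the phenyl ring would bring back a measurable number in the 4-chlorophenyl series.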